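A few compounds are considered here, and "the series" means these few. Any claim that something is new, unique, unknown or untested is made for them only; others in the source may bear on it.

Compound 1, `CCN(CC)C(=O)c1ccccc1OCC1=NCCN1`. In a functional assay for activation of Alpha-1B adrenergic receptor (Homo sapiens), read by calcium flux (on this read-out lower numbers stand for an effect already at smaller amounts and higher numbers for an effect only at larger amounts of compound), compound 1 gives < 5020 nM, which is a limit of the assay and not a number.
Compound 2, `Cc1ccnc(-c2ccccc2OCC2=NCCN2)c1`. In this assay compound 2 gives < 100000 nM, again a limit rather than a number.
Compound 3, `c1ccc(-c2cnccn2)c(OCC2=NCCN2)c1`. In this assay compound 3 gives 631 nM.

Within the data shown here, compound 3 therefore stands as the only compound with a measured number; the other two values are limits, one sitting at the limit of < 100000 nM in this assay, at which 1 of the 3 values shown sits, and one at the limit of < 5020 nM in this assay, at which 1 of the 3 values shown sits. Among the measured compounds shown here, no two measured compounds differ in just one place, so no measured step exists to guide the next change.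

Compound 4, `c1ccc(-c2ccns2)c(OCC2=NCCN2)c1`, is not yet measured. It differs from compound 3 by 1,2-thiazol-5-yl in place of pyrazin-2-yl on an aromatic carbon; in words, 1,2-thiazol-5-yl in place of pyrazin-2-yl on an aromatic carbon. Both groups are small aromatic rings carrying two hetero atoms, so a step of a 1.3-fold higher number from compound 3 to compound 4 (0.10 log units; within the scatter) is expected, which would stay within the usual scatter of repeated measurements. Compound 4 is estimated to give 800 nM in this assay, with a likely range from 250 nM to 2500 nM.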

Compound 4, half-maximal effective concentration: 12.6 nM
The estimate for compound 4 lay 63-fold (1.80 log units) above the measured number; measured number below the stated range.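

Exchanging pyrazin-2-yl for 1,2-thiazol-5-yl on this aromatic carbon brings a 50-fold lower number from compound 3 to compound 4 (1.70 log units; beyond the scatter) in this assay, so the choice of ring at this position can matter greatly. The two groups have equal counts of hetero atoms, hydrogen-bond donors and hydrogen-bond acceptors, so those counts alone do not set the read-out; the groups differ in ring size and in the sulfur that enters. Nothing shown here explains why this change has so large an effect.

Still open, from the compounds shown here alone, is whether the sulfur or the five-membered ring accounts for the step, a question that a 1,2-oxazol-5-yl group, with oxygen in place of sulfur, could help to separate. A plain phenyl group at the same position would show how each ring compares with a ring of carbon only.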